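This account rests on a few compounds, and the source may have more. Where it says the series, first, only, none or still open, it means among the compounds named here.

Measured so far:
compound 1 `COc1cc(C(=O)NNC(=S)Nc2csc(-c3ccc(C)cc3)c2)cc(OC)c1OC` — 13000 nM
compound 2 `COc1cc(OC)cc(C(=O)NNC(=S)Nc2csc(-c3ccccc3)c2)c1` — 30000 nM

Going by the values given here, in a functional assay on B16-F10 cells (Mus musculus) for inhibition, read by colorimetric assay and MTT assay, with a stated time of 72 h (on this read-out lower numbers stand for stronger inhibition and higher numbers for weaker inhibition), compound 2 gives 30000 nM, the highest of the two numbers known; compound 1 sits a step beyond the scatter below it, though the two differ in more than one place, so no single cause can be read from that gap. Compound 3 `COc1cc(OC)cc(C(=O)NNC(=S)Nc2csc(-c3ccc(C)cc3)c2)c1` differs from compound 2 by methyl in place of hydrogen on an aromatic carbon. Among the compounds with values here, since no measured pair shows this change alone, a small step, if any, is expected, leaning toward a lower number; the estimated step from compound 2 to compound 3 is a 1.5-fold lower number from compound 2 to compound 3 (0.18 log units; within the scatter). Compound 3 is estimated at 20000 nM, ranging from 8000 nM to 50000 nM.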

Compound 3, half-maximal inhibitory concentration: 13000 nM
Compound 3: the middle estimate sits 1.5-fold (0.19 log units) above what was measured, within the range that was stated.
By their numbers in this assay, from the lowest: compounds 1 and 3 (each within the scatter of the next); then compound 2.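

In this assay, the change from phenyl to 4-methylphenyl can now be read alone, and it gives a 2.3-fold lower number from compound 2 to compound 3 (0.36 log units; beyond the scatter), a modest gain. Hydrogen in place of methoxy on the other aromatic ring, also seen alone for the first time, gives no change at the digits printed from compound 1 to compound 3 (within the scatter), so that methoxy shows no effect on this read-out when the 4-methylphenyl group is present. Nothing here explains either result. Going by these compounds, whether a larger group such as ethyl, or an amine, in place of the methyl would lower the number further remains open. So does whether the methoxy group would also make no difference on a plain phenyl.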